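Replacing the tert-butylphenyl of compound 3 with dimethoxyphenyl

The compounds below may be only part of what the source reports. "The series", "measured", "known", "first", "only" and "open" are said of these compounds alone.

Measured compounds:
compound 1 `CCCN(CCC)c1cc(C(F)(F)F)ccc1CNC(=O)C(C)c1ccc(NS(C)(=O)=O)c(F)c1` 0.3 nM
compound 2 `CC(C)CCOc1cc(C(F)(F)F)ccc1CNC(=O)C(C)c1ccc(NS(C)(=O)=O)c(F)c1` 0.5 nM
compound 3 `CC(C(=O)NCc1ccc(C(F)(F)F)cc1-c1ccc(C(C)(C)C)cc1)c1ccc(NS(C)(=O)=O)c(F)c1` 1.1 nM

In an assay on CHO cells for antagonist activity at transient receptor potential cation channel subfamily V member 1 (Homo sapiens), read by FLIPR (a lower number here means a stronger inhibitor, a higher number a weaker inhibitor), compound 3 stands highest of the three numbers; its nearest neighbour is compound 2, and the steps of a 2.2-fold higher number from compound 2 to compound 3 (0.34 log units; beyond the scatter) and a 3.7-fold higher number from compound 1 to compound 3 (0.56 log units; beyond the scatter) are both modest. Compound 4 `COc1ccc(-c2cc(C(F)(F)F)ccc2CNC(=O)C(C)c2ccc(NS(C)(=O)=O)c(F)c2)cc1OC` differs from compound 3 by 3,4-dimethoxyphenyl in place of 4-(tert-butyl)phenyl on an aromatic carbon. For the measured compounds named here, no measured step covers this change; the two steps that end at compound 3 only show that exchanging the group at this aromatic carbon moves the number modestly. A step of similar size is therefore expected, with the direction uncertain, and the estimate leans to a somewhat higher number a 2.7-fold higher number from compound 3 to compound 4 (0.44 log units; beyond the scatter). Compound 4 is thus expected at 3 nM, within 0.8 nM to 12 nM.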

Compound 4, inhibition constant: 8.6 nM
The estimate for compound 4 lay 2.9-fold (0.46 log units) below the measured number; the measured number falls inside the stated range.
By their numbers in this assay, from the lowest: compounds 1 and 2 (each within the scatter of the next); then compound 3; then compound 4.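

In this assay, the choice of aryl group at this aromatic carbon matters: 3,4-dimethoxyphenyl in place of 4-(tert-butyl)phenyl gives a 7.8-fold higher number from compound 3 to compound 4 (0.89 log units; beyond the scatter), although both groups have the same heavy-atom count. For the compounds shown here, measured against isopentyloxy and dipropylamino, the change reaches a 17-fold higher number from compound 2 to compound 4 (1.24 log units; beyond the scatter) and a 29-fold higher number from compound 1 to compound 4 (1.46 log units; beyond the scatter), both large, whereas the earlier steps at this carbon were at most modest. No measured evidence accounts for this change. The compounds shown leave open whether a 4-methoxyphenyl or an unsubstituted phenyl group would stay close to compound 3 or to compound 4.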